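Amide substituent swap on an antiproliferative scaffold

A few compounds are considered here, and "the series" means these few. Any claim that something is new, unique, unknown or untested is made for them only; others in the source may bear on it.

Compounds measured so far:
Compound 1, `CCn1c(C(=O)N[C@H](C)C(=O)OC)ccc1C(CC)(CC)c1ccc(OCS(=O)(=O)c2ccccc2)c(C)c1`: > 50000 nM
Compound 2, `CCn1c(C(=O)N[C@@H](CC(=O)OC)C(=O)OC)ccc1C(CC)(CC)c1ccc(OCS(=O)(=O)c2ccccc2)c(C)c1`: > 50000 nM
Compound 3, `CCn1c(C(=O)NCCO)ccc1C(CC)(CC)c1ccc(OCS(=O)(=O)c2ccccc2)c(C)c1`: 15500 nM

In a functional assay on MCF7 cells (Homo sapiens) for antiproliferative activity, read by MTT assay, with a stated time of 24 h (on this read-out lower numbers stand for stronger inhibition and higher numbers for weaker inhibition), compound 1 gives only a limit of the assay, > 50000 nM. The same limit is shared by compound 2, so the step that the two limits leave unreadable from compound 1 to compound 2 stays unreadable; the limit of > 50000 nM in this assay, at which 2 of the 3 values shown sit, is where two of the three values sit. Going by the values given here, compound 3 is the one compound with a number, and the steps of an at least 3.2-fold lower number from compound 1 to compound 3 (0.50 log units; beyond the scatter) and an at least 3.2-fold lower number from compound 2 to compound 3 (0.50 log units; beyond the scatter) show a lower number arriving with the 2-hydroxyethyl group.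

Compound 4, `CCn1c(C(=O)N[C@@H](CO)C(C)C)ccc1C(CC)(CC)c1ccc(OCS(=O)(=O)c2ccccc2)c(C)c1`, is not yet measured. Its change from compound 1 is 1-(hydroxymethyl)-2-methylpropyl in place of 1-(methoxycarbonyl)ethyl on an amide-type nitrogen. The entering group carries a hydroxyl, as the 2-hydroxyethyl of compound 3 does, so the step from compound 1 to compound 3 is the nearest guide, though the change differs in shape. A step of an at least 2.0-fold lower number from compound 1 to compound 4 (0.30 log units; that floor lies within the scatter) is expected, and compound 4 is estimated at 25000 nM, within 8000 nM to 60000 nM.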

Compound 4, half-maximal inhibitory concentration: 18800 nM
The estimate for compound 4 lay 1.3-fold (0.12 log units) above the measured number, within the range that was stated.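

With an at least 2.6-fold lower number from compound 1 to compound 4 (0.42 log units; beyond the scatter) and an at least 2.6-fold lower number from compound 2 to compound 4 (0.42 log units; beyond the scatter), a second hydroxyl-bearing group, 1-(hydroxymethyl)-2-methylpropyl, joins the 2-hydroxyethyl of compound 3 in giving a number rather than a limit. Set against that smaller group, the added isopropyl gives a 1.2-fold higher number from compound 3 to compound 4 (0.08 log units; within the scatter), so on this amide-type nitrogen the branch makes no readable difference.

As far as these compounds go, how far compound 1 and compound 2 truly lie stays unknown, leaving their steps as floors only: the limit of > 50000 nM in this assay, at which 2 of the 4 values shown sit. Also open is whether an amine or a carboxylic acid in place of the hydroxyl on this chain would give a number at all.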